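The source may report more compounds than this note shows. Statements on the series, on what has been measured and on what is new or still open speak of the compounds shown alone.

Measured so far:
compound 1 `NS(=O)(=O)NNc1nonc1/C(=N/O)Nc1ccc(F)c(Br)c1` — 101 nM
compound 2 `C#CCNS(=O)(=O)CCNc1nonc1/C(=N/O)Nc1ccc(F)c(Br)c1` — 33 nM

In an assay on HeLa cells for inhibition of Indoleamine 2,3-dioxygenase 1 (Homo sapiens), read by spectrophotometry, with a stated time of 24 h (on this read-out lower numbers stand for an effect already at smaller amounts and higher numbers for an effect only at larger amounts of compound), compound 2 gives the lowest of the two numbers at hand; its nearest neighbour is compound 1, and the step of a 3.1-fold lower number from compound 1 to compound 2 (0.49 log units; beyond the scatter) lies beyond the scatter. Compound 3 `NNS(=O)(=O)CCNc1nonc1/C(=N/O)Nc1ccc(F)c(Br)c1` is not yet measured. It differs from compound 2 by amino in place of propargyl on a sulfonamide nitrogen. Within the data shown here, only the step from compound 1 to compound 2 bears on this change, and it is an imperfect guide: it alters both the linker and the terminal group at once, whereas compound 3 keeps the ethyl linker of compound 2 and only exchanges the group on the sulfonamide nitrogen. The terminal amino of compound 3 brings it closer to compound 1 in that respect, so the number for compound 3 is expected to sit between the two measured values, with the step of a 1.8-fold higher number from compound 2 to compound 3 (0.26 log units; within the scatter) expected. The estimate for compound 3 in this assay is 60 nM, with a range from 20 nM to 180 nM.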

Compound 3, half-maximal effective concentration: > 800 nM
Compound 3 ended at the assay's limit; the forecaster's own chance of this, stated with the estimate: 3%; at least 13-fold (1.12 log units) between middle value and limit.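

In this assay compound 3 gives > 800 nM, which is a limit of the assay and not a number. On the sulfonamide nitrogen, amino in place of propargyl gives an at least 24-fold higher number from compound 2 to compound 3 (1.38 log units; beyond the scatter), so this position is sensitive to the group it carries, which the earlier step could not show since it changed linker and terminal group together. Replacing sulfamoylamino with 2-(aminosulfamoyl)ethyl gives an at least 7.9-fold higher number from compound 1 to compound 3 (0.89 log units; beyond the scatter), so the ethyl linker alone does not account for the lower number of compound 2.

Going by these compounds, whether the rise comes from adding amino or from losing propargyl stays open; a methyl group, a propyl group or an unsubstituted sulfonamide on the same nitrogen would help separate the two. The actual value of compound 3 also stays open, since the record holds only this: the limit of > 800 nM in this assay, at which 1 of the 3 values shown sits.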